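Removing a Nitro Group from a Styryl Piperidine Series

The source may hold more compounds than are shown below. What is called first, only, known or untested is meant among the compounds shown, and "the series" means these compounds.

Measured compounds:
Compound 1, `CN1CCCC[C@H]1/C=C/c1ccc(O)cc1`, 3.45 ug/mL
Compound 2, `Cc1cccc(C)c1/C=C/[C@@H]1CCCCN1`, 7.28 ug/mL
Compound 3, `O=[N+]([O-])c1ccc(/C=C/[C@@H]2CCCCN2)cc1`, 3.27 ug/mL

Of the compounds shown here, three have been measured in a functional assay on A549 cells (Homo sapiens) for inhibition, read by MTT assay, with a stated time of 24 h; on this read-out higher numbers stand for weaker inhibition and lower numbers for stronger inhibition. Compound 3, with the structure `O=[N+]([O-])c1ccc(/C=C/[C@@H]2CCCCN2)cc1`, gives 3.27 ug/mL, the lowest number of the three. Its nearest neighbour is compound 1, whose value of 3.45 ug/mL lies within the usual scatter of it, so no order can be drawn between the two. Compound 2, at 7.28 ug/mL, lies beyond the scatter from compound 3 and so stands apart with a higher number.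

The next compound, compound 4, has the structure `C(=C/[C@@H]1CCCCN1)\c1ccccc1` and has not yet been measured in this assay. It differs from compound 3 in one place: hydrogen in place of nitro on an aromatic carbon.

Among the measured compounds shown here, no measured pair in this set differs in just one place, so there is no step of the same kind to lean on. The three values together span a narrow range, and the measured compound lacking a substituent pattern like that of compound 3, compound 2, sits at the higher end. Compound 4 is therefore expected to give a somewhat higher number than compound 3, a step of a 1.5-fold higher number from compound 3 to compound 4 (0.18 log units; within the scatter) in this assay, close to the edge of the scatter. The estimate for compound 4 is 5 ug/mL, with a range from 2.5 ug/mL to 10 ug/mL.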

Compound 4, half-maximal inhibitory concentration: 9.99 ug/mL
Compound 4: the middle estimate sits 2.0-fold (0.30 log units) below what was measured; measured number inside the range.
By their numbers in this assay, from the lowest: compounds 3 and 1 (each within the scatter of the next); then compounds 2 and 4 (each within the scatter of the next).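

Among the compounds shown here, exchanging the nitro group for hydrogen on the aromatic carbon gives a 3.1-fold higher number from compound 3 to compound 4 (0.49 log units; beyond the scatter) in this assay, and this is the first pair in the set that differs in one place only. The earlier compounds shown here could not isolate this position, whereas this pair shows that the group on the aromatic carbon para to a group of 8 heavy atoms matters on this core: with the rest of the structure unchanged, the nitro group goes with the lower number and so with stronger inhibition. The pair records that link but does not explain it, and no measurement shown here accounts for the size of the step.

From the compounds shown here alone, whether the lower number is particular to the nitro group remains open, as a single exchange cannot show how a nitrile, a carboxylic acid or an amine at the same place on the core of compound 3 would compare. Also open, going by these compounds, is whether a nitro group in place of hydrogen would bring a step of similar size on a core carrying other changes, such as the methyl group on the ring nitrogen of compound 1.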